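The source may report more compounds than this note shows. Statements on the series, on what has been measured and on what is new or still open speak of the compounds shown alone.

Of the compounds shown here, three sharing one core have been measured in a functional assay on MCF7 cells (Homo sapiens) for antiproliferative activity, read by sulforhodamine B assay, with a stated time of 48 h; a higher number here means a weaker inhibitor, a lower number a stronger inhibitor. Compound 1 `CC(=O)Nc1cccc(S(=O)(=O)Oc2ccccc2C(C)C)c1` gives 21000 nM, and compound 2 `CCCC(=O)Nc1cccc(S(=O)(=O)Oc2ccccc2C(C)C)c1` gives 9400 nM. Compound 3 `CC(=O)Nc1ccc(S(=O)(=O)Oc2ccccc2I)cc1` gives 27000 nM, the highest number of the three, though its gap to compound 1 lies within the scatter, while compound 2 sits clearly lower. Compound 4 `CCC(=O)Nc1ccc(S(=O)(=O)Oc2ccccc2I)cc1` differs from compound 3 by methyl in place of hydrogen on a saturated chain carbon bound to a carbonyl carbon. Within the data shown here, the only measured step at the same place is a 2.2-fold lower number from compound 1 to compound 2 (0.35 log units; beyond the scatter), where ethyl entered rather than methyl. Since the new change is the shorter version of that one, a shift in the same direction, of similar or smaller size, is expected in this assay, so the expected step is a 1.5-fold lower number from compound 3 to compound 4 (0.18 log units; within the scatter). Compound 4 is therefore estimated at 18000 nM, with a range from 9000 nM to 36000 nM.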

Compound 4, half-maximal inhibitory concentration: 8100 nM
Estimate against measurement, compound 4: 2.2-fold (0.35 log units) above; the whole stated range lies above it.
By their numbers in this assay, from the lowest: compounds 4 and 2 (each within the scatter of the next); then compounds 1 and 3 (each within the scatter of the next).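

In this assay, adding one methyl on the saturated chain carbon bound to a carbonyl carbon gives a 3.3-fold lower number from compound 3 to compound 4 (0.52 log units; beyond the scatter) and so, on its own, moves the number beyond the scatter. With a 2.2-fold lower number from compound 1 to compound 2 (0.35 log units; beyond the scatter) on the other pair, the number falls in both pairs when the chain at this place grows, even though the two pairs differ elsewhere in the molecule. Nothing available here gives a cause for this fall. As far as these compounds go, whether a longer chain on compound 4 would lower the number further remains open. So does the outcome with an amine or a carboxylic acid at this place.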